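A few compounds are considered here, and "the series" means these few. Any claim that something is new, unique, unknown or untested is made for them only; others in the source may bear on it.

For the measured compounds named here, in a functional assay on K562 cells (Homo sapiens) for cytotoxicity, read by trypan blue exclusion, with a stated time of 96 h (on this read-out higher numbers stand for weaker inhibition and lower numbers for stronger inhibition), compound 1 `COc1ccc(CS(=O)(=O)/C=C/c2c(OC)cccc2OC)c([N+](=O)[O-])c1` gives 50000 nM, the higher of the two numbers measured so far, which makes it the weaker of the pair. Going by the values given here, its only measured neighbour, compound 2 `COc1ccc(CS(=O)(=O)/C=C/c2c(OC)cccc2OC)c(N)c1`, gives 750 nM. The next structure to consider is compound 3 `COc1cc(OC)c(/C=C/S(=O)(=O)Cc2ccc(OC)cc2[N+](=O)[O-])c(OC)c1`, which keeps the nitro group of compound 1. The change is methoxy in place of hydrogen on an aromatic carbon, meta to two methoxy groups and para to a large group. Among the compounds with values here, the only measured step, a 67-fold lower number from compound 1 to compound 2 (1.82 log units; beyond the scatter), is a large one, and it came with amino in place of nitro. That is a different change at a different place, so it bears only indirectly: it shows that one substitution on this core can move the number a long way. Within the data shown here, no measured step adds a methoxy, so the size of this one remains uncertain. A moderate move towards stronger inhibition in this assay seems most likely, and the expected step is an 8.3-fold lower number from compound 1 to compound 3 (0.92 log units; beyond the scatter). For compound 3 the estimated value is 6000 nM, with an expected range of 600 nM to 50000 nM.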

Compound 3, half-maximal inhibitory concentration: 20000 nM
Estimate against measurement, compound 3: 3.3-fold (0.52 log units) below; the measured number falls inside the stated range.
By their numbers in this assay, from the lowest: compound 2; then compound 3; then compound 1.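

Adding a methoxy group at this place, meta to two methoxy groups and para to a large group, does change the result in this assay: the step is a 2.5-fold lower number from compound 1 to compound 3 (0.40 log units; beyond the scatter). For the compounds shown here, this is the first measured sign that the position can take an added group with no loss of strength, and here the number moves towards stronger inhibition. The gain is modest beside the large 67-fold lower number from compound 1 to compound 2 (1.82 log units; beyond the scatter), so on compound 1 the swap of nitro for amino counts for more than this added methoxy, and no measured information explains why this methoxy lowers the number.

Compound 3 still carries the nitro group, so the compounds shown leave open whether the same methoxy would also lower the number on the amino-bearing compound 2. They also leave open whether the gain is specific to methoxy or would appear with another group at this place, such as a hydroxyl, a chlorine atom or the longer ethoxy.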